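Aryl exchange on the ring amine nitrogen: compound 4

This account rests on a few compounds, and the source may have more. Where it says the series, first, only, none or still open, it means among the compounds named here.

Measured compounds:
compound 1, `Nc1scc(CN2CCN(c3ccc(F)cc3Cl)CC2)c1C(=O)c1ccc(Cl)cc1` — -6.2%
compound 2, `Nc1scc(CN2CCN(c3ccc(OC(F)(F)F)cc3)CC2)c1C(=O)c1ccc(Cl)cc1` — -13%
compound 3, `Nc1scc(CN2CCC(c3ccc(Cl)cc3)CC2)c1C(=O)c1ccc(Cl)cc1` — -2.3%

All three values come from a functional assay on CHO cells with adenosine receptor A1 (Homo sapiens) as the target, read by cAMP accumulation and immunoassay, with a stated time of 6 min, tested at 0.1 uM; a higher number here means a weaker effect of the compound at the concentration tested, a lower number a stronger effect. Compound 2 stands lowest of the three numbers. Its nearest neighbour is compound 1, a number higher but within the scatter; the furthest is compound 3, higher by an amount beyond the scatter. For the measured compounds named here, the one step between measured compounds that differ in a single place is a number 6.8 percentage points lower from compound 1 to compound 2 (within the scatter), and it lies within the scatter.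

Compound 4, `Nc1scc(CN2CCN(c3cc(F)cc(F)c3)CC2)c1C(=O)c1ccc(Cl)cc1`, differs from compound 2 in one place: 3,5-difluorophenyl in place of 4-(trifluoromethoxy)phenyl on an amine nitrogen in a ring. Going by the values given here, the only measured step that bears on this change is the aryl exchange on the same amine nitrogen, a number 6.8 percentage points lower from compound 1 to compound 2 (within the scatter), which moved the number by less than the scatter. Among the compounds with values here, no step involving a 3,5-difluorophenyl group is known. On that basis the change from compound 2 to compound 4 is expected to give no step beyond the scatter, which the estimate expresses as a number 5 percentage points higher from compound 2 to compound 4 (within the scatter).

In this assay compound 4 is therefore expected to read about -8%, with an expected range from -20% to 5%.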

Compound 4, a percentage reported as activity, at one concentration (the size of the read-out at that concentration, not a potency): -5%
The estimate for compound 4 lay 3 percentage points below the measured number, within the range that was stated.
By their numbers in this assay, from the lowest: compounds 2, 1, 4 and 3 (each within the scatter of the next, the first and the last beyond it).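

In this assay, 3,5-difluorophenyl on the ring amine nitrogen gives a number within the scatter of both earlier aryl groups at this position, with a number 8 percentage points higher from compound 2 to compound 4 (within the scatter) and a number 1.2 percentage points higher from compound 1 to compound 4 (within the scatter). With compound 4, the three aryl groups on this nitrogen, in compounds 1, 2 and 4, show no step beyond the scatter, and none of the three compounds goes against this. This holds although the change from compound 2 to compound 4 replaces 11 heavy atoms and 1 hydrogen-bond acceptor with 8 heavy atoms and 0 hydrogen-bond acceptors, and no available evidence bears on why these numbers stay within the scatter.

Still open, as far as these compounds go, is whether a benzyl group in place of the aryl group on this nitrogen, or a carboxylic acid or an amine carried on the aryl group, would move the number beyond the scatter. The read-out comes from one concentration, so it leaves open whether compounds 1, 2 and 4 would also stay within the scatter of one another at other concentrations.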